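A few compounds are considered here, and "the series" means these few. Any claim that something is new, unique, unknown or untested is made for them only; others in the source may bear on it.

Series notes:

- compound 1 `CCCCC#Cc1c(C)[nH]c2ccc(OC)cc2c1=O`: > 36800 nM (a limit)
- compound 2 `CCCCC#Cc1c(C)[nH]c2ccc(Cl)cc2c1=O`: > 36300 nM (a limit)
- compound 3 `CCCCC#Cc1c(C)[nH]c2ccc(F)cc2c1=O`: > 38600 nM (a limit)
- compound 4 `CCCCC#Cc1c(C)[nH]c2cc(OC)c(Cl)cc2c1=O`: not yet measured

All three measured compounds in an ADME assay on J774 cells (Mus musculus) for cytotoxicity (a lower number here means that less compound is needed, a higher number that more compound is needed for the effect), return limits, so no number is available for ranking them. Compound 2 gives > 36300 nM, which is a limit and not a number. The other two compounds also stand only at limits, so compound 2 has no readable place relative to them.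

The change under consideration is methoxy in place of hydrogen on an aromatic carbon, ortho to a chloro group. The chloro group of compound 2 stays in compound 4.

For the measured compounds named here, three measured steps touch the same part of the core: a step that the two limits leave unreadable from compound 1 to compound 2, a step that the two limits leave unreadable from compound 1 to compound 3 and a step that the two limits leave unreadable from compound 2 to compound 3. None of them has a readable size, and none replaces a hydrogen with methoxy. Compound 1 also carries a methoxy group. Compound 1 gives > 36800 nM, which is likewise a limit.

With this evidence, no step beyond the scatter is expected in this assay, in either direction. The expected step is an at least 1.1-fold lower number from compound 2 to compound 4 (0.04 log units; that floor lies within the scatter). The most likely report for compound 4 is again a limit rather than a number. For compound 4 the estimate is 33000 nM, with an expected range from 15000 nM to 45000 nM.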

Compound 4, half-maximal effective concentration in the J774 assay: 15000 nM
Estimate against measurement, compound 4: 2.2-fold (0.34 log units) above; the measured number falls inside the stated range.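

For the compounds shown here, in the J774 assay methoxy in place of hydrogen on an aromatic carbon, ortho to a chloro group, gives the first readable step: an at least 2.4-fold lower number from compound 2 to compound 4 (0.38 log units; beyond the scatter). Going by these compounds alone, the steps among compound 1, compound 2 and compound 3 cannot be read, as all three values are limits, so this aromatic carbon is the only place on the shared core where a change in this read-out shows in the compounds so far. In a physicochemical assay for solubility, read by HPLC, at pH 7.4 (on this read-out lower numbers stand for lower solubility and higher numbers for higher solubility), the same change also gives a step in the opposite numerical direction: an at least 10-fold higher number from compound 2 to compound 4 (1.00 log units; beyond the scatter).

In the physicochemical assay compound 2 gives 2000 nM. As far as these compounds go, in the physicochemical assay compound 4 gives > 20000 nM, which is a limit, so the full size of that step stays open, as does the full size of the step in the J774 assay. From the compounds shown here alone, whether both steps belong to methoxy itself or would also appear with ethoxy, a hydroxyl group or an amine on this carbon stays open, as does whether methoxy here would do the same without the chloro group.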